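The source may hold more compounds than are shown below. What is called first, only, known or untested is meant among the compounds shown, and "the series" means these compounds.

Going by the values given here, compound 2 `CSCC[C@H](NC(=O)CN(c1nc(Cl)nc2[nH]cnc12)C1CC1)C(=O)O` stands lowest of the two numbers so far: in a functional assay on the whole organism (Tail, strain ICR) with Mus musculus as the target, in the tail flick test, with a stated time of 120 min, at a dose of 25 umol/kg by the oral route (a higher number here means a stronger effect of the compound at the dose given, a lower number a weaker effect), compound 2 gives 5.67%, while compound 1 `CSCC[C@H](NC(=O)CN(c1nc(Cl)nc2[nH]cnc12)C1CC1)C(=O)OCc1ccccc1` gives 31.6%. Compound 3 `CC(C)C[C@H](NC(=O)CN(c1nc(Cl)nc2[nH]cnc12)C1CC1)C(=O)O` differs from compound 2 by isopropyl in place of (methylsulfanyl)methyl on a saturated chain carbon, two bonds along the chain from an amide-type nitrogen and a carbonyl carbon. Among the compounds with values here, the only measured step, a number 25.9 percentage points lower from compound 1 to compound 2 (beyond the scatter), is a change of a different kind and does not bear on this one, so there is no measured guide to the present change. Compound 3 is therefore expected to shift by a number 1.3 percentage points higher from compound 2 to compound 3 (within the scatter), not beyond the scatter. The estimate for compound 3 is 7%, within a range from 0% to 22%.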

Compound 3, a percentage reported as activity, at one dose (the size of the read-out at that dose, not a potency): 18.7%
For compound 3 the middle estimate is 11.7 percentage points below the measured one, within the range that was stated.
By their numbers in this assay, from the lowest: compound 2; then compound 3; then compound 1.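

In this assay, the group on the saturated chain carbon, two bonds along the chain from an amide-type nitrogen and a carbonyl carbon, proves able to move the read-out among the free acids: isopropyl in place of (methylsulfanyl)methyl brings a number 13 percentage points higher from compound 2 to compound 3 (beyond the scatter) in this single pair. The earlier compounds shown here showed a change only at the ester oxygen, not here. Nothing available explains this step. As far as these compounds go, it remains open whether an amine or a longer chain at this carbon would go further, and whether a benzyl ester on compound 3 would raise its number too.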